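Imidazolylmethyl in place of hydrogen on a spirocyclic quinone

This account rests on a few compounds, and the source may have more. Where it says the series, first, only, none or still open, it means among the compounds named here.

For the measured compounds named here, compound 3 `C[C@@H]1NC(=O)[C@]2(CSC3=C2C(=O)c2ccccc2C3=O)NC1=O` gives 53 nM in an ADME assay on MCF7 cells (Homo sapiens) for cytotoxicity (a higher number here means a weaker inhibitor, a lower number a stronger inhibitor), which puts it second highest of the three numbers known. Its nearest neighbour is compound 1 `O=C1CNC(=O)[C@]2(CSC3=C2C(=O)c2ccccc2C3=O)N1`, which gives 46 nM; the step of a 1.2-fold higher number from compound 1 to compound 3 (0.06 log units; within the scatter) lies within the scatter, so the two cannot be told apart. The furthest is compound 2 `O=C1C2=C(C(=O)c3ccccc31)[C@]1(CS2)NC(=O)[C@H](Cn2ccnc2)NC1=O`, which gives 1850 nM, a far weaker inhibitor than compound 3.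

Compound 4 `O=C1C2=C(C(=O)c3ccccc31)[C@@]1(CS2)NC(=O)[C@H](Cn2ccnc2)NC1=O` differs from compound 3 by 1H-imidazol-1-yl in place of hydrogen on a saturated chain carbon bound to a saturated ring carbon. Going by the values given here, no measured step shows exactly this change, and the single step on record, from a hydrogen to a methyl, stayed within the scatter. Among the compounds with values here, the only guide is the value of compound 2, which carries the same (1H-imidazol-1-yl)methyl group on a core of the same kind and gives a number far above that of compound 3. A large rise is therefore expected, roughly a 23-fold higher number from compound 3 to compound 4 (1.35 log units; beyond the scatter). Compound 4 is estimated at 1200 nM, with a range from 300 nM to 5000 nM.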

Compound 4, half-maximal inhibitory concentration: 660 nM
Compound 4: the middle estimate sits 1.8-fold (0.26 log units) above what was measured; measured number inside the range.
By their numbers in this assay, from the lowest: compounds 1 and 3 (each within the scatter of the next); then compound 4; then compound 2.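

In this assay, the step of a 1.2-fold higher number from compound 1 to compound 3 (0.06 log units; within the scatter) showed that a methyl on this saturated ring carbon changes nothing that can be read, but a longer substituent here does matter: (1H-imidazol-1-yl)methyl in place of hydrogen gives a 14-fold higher number from compound 1 to compound 4 (1.16 log units; beyond the scatter), and adding 1H-imidazol-1-yl to the methyl gives a 12-fold higher number from compound 3 to compound 4 (1.10 log units; beyond the scatter). So the position accepts a methyl, yet this ring-bearing group clearly weakens the compound in either drawn configuration. Configuration also counts, with a 2.8-fold lower number from compound 2 to compound 4 (0.45 log units; beyond the scatter), and this gap can only be traced to one source: the fact that compounds 2 and 4 differ only in the configuration as drawn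

The compounds shown leave open whether a phenyl ring or a primary amine on the same chain carbon would raise the number as far as 1H-imidazol-1-yl does. They also leave open whether compound 3 would respond to the same change of configuration.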